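Working notes: cytotoxicity across three analogues and a fourth

The source may report more compounds than this note shows. Statements on the series, on what has been measured and on what is new or still open speak of the compounds shown alone.

Three members of the series have been run in an ADME assay on HeLa cells (Homo sapiens) for cytotoxicity, read by ATP content, with a stated time of 3 days; a higher number here means that more compound is tolerated, a lower number that less compound is tolerated. Compound 1 `O=c1n(Cc2cc3cnccc3n2CCCCF)c2cnccc2n1C1CC1` reaches only the assay limit, > 50000 nM. Compound 2 `CS(=O)(=O)CCCn1c(Cn2c(=O)n(C3CC3)c3ccncc32)nc2nc(Cl)ccc21` likewise stops at the limit, > 50000 nM. Compound 3 `COc1ccc(-n2c(=O)n(Cc3cc4cc(Cl)ccc4n3CCCC#N)c3cnccc32)cc1OC` also gives a limit rather than a number, > 50000 nM. Among the compounds with values here, all three values therefore sit at the same place, (the limit of > 50000 nM in this assay, at which 3 of the 3 values shown sit), and no step between measured compounds can be sized.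

Compound 4 `Cc1ccc(-n2c(=O)n(Cc3cc4cc(Cl)ccc4n3CCCC#N)c3cnccc32)cc1` differs from compound 3 in one place: 4-methylphenyl in place of 3,4-dimethoxyphenyl on an aromatic nitrogen. With every value so far at the limit, there is no shown step from which a direction could be read; the expectation is no step beyond the scatter in this assay, that is a number no higher from compound 3 to compound 4 (the limit leaves the size open). Compound 4 is expected to give 50000 nM, within 30000 nM to 100000 nM, most likely reported once more as a limit.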

Compound 4, half-maximal cytotoxic concentration: > 50000 nM
Compound 4: only a limit was reported (the forecaster's own chance of this, stated with the estimate: 85%); the middle value lies on the limit itself.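

Within the data shown here, compound 3 and compound 4 both stop at a limit in this assay, so no step between them can be read. The compounds shown leave open how far tolerance extends past that limit and whether any single change alters it.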